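A few compounds are considered here, and "the series" means these few. Any claim that something is new, unique, unknown or untested is made for them only; others in the source may bear on it.

Measured so far:
compound 1 `N#C/C(=C\c1c(F)c(F)c(F)c(F)c1F)C(=O)c1c[nH]c2ccccc12` — 18000 nM
compound 2 `COc1ccc(CNC(=O)/C(C#N)=C/c2ccc[nH]2)cc1` — > 50000 nM

In a functional assay on SW480 cells (Homo sapiens) for inhibition, read by MTT assay, with a stated time of 72 h (a lower number here means a stronger inhibitor of growth, a higher number a weaker inhibitor of growth), compound 1 gives 18000 nM. For compound 2 the result is a limit of the assay, not a number: > 50000 nM. Compound 2 therefore sits at the limit of > 50000 nM in this assay, at which 1 of the 2 values shown sits, the upper edge of what has been measured here.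

Compound 3 `COc1ccc(CNC(=O)/C(C#N)=C/c2ccc(Cl)o2)cc1` differs from compound 2 by 5-chlorofuran-2-yl in place of 1H-pyrrol-2-yl on a double-bonded chain carbon bound to a double-bonded chain carbon. Within the data shown here, no measured step connects two compounds differing only in this way, so there is nothing to anchor the change. The expected step of a number no higher from compound 2 to compound 3 (the limit leaves the size open) in this assay is none beyond the scatter, with a fair chance of another limit. Compound 3 is estimated at 50000 nM, within 15000 nM to 150000 nM.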

Compound 3, concentration for 50% growth inhibition: 13000 nM
Estimate against measurement, compound 3: 3.8-fold (0.59 log units) above, outside the stated range (below it).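

In this assay, 5-chlorofuran-2-yl in place of 1H-pyrrol-2-yl gives an at least 3.8-fold lower number from compound 2 to compound 3 (0.58 log units; beyond the scatter). This place on the double-bonded chain carbon therefore responds to the group it carries, and the change brings the series from a limit to a measurable number. The full size of the step stays open because compound 2 is only a limit: the limit of > 50000 nM in this assay, at which 1 of the 3 values shown sits.

Which part of the change carries the step remains open, since the ring hetero atom and the chlorine change together here. A plain furan-2-yl at this place would separate the two.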